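Swapping Bromo for Amino on a Shared Core

The source may hold more compounds than are shown below. What is called first, only, known or untested is meant among the compounds shown, and "the series" means these compounds.

Measured compounds:
compound 1 `O=C(NC(=S)Nc1nc2cc(Br)ccc2s1)N1CCOCC1` — 20300 nM
compound 2 `O=C(NC(=S)Nc1nc2cc(Br)ccc2s1)c1cccs1` — 15700 nM

Of the compounds shown here, two sharing one core have been measured in a functional assay on MCF7 cells (Homo sapiens) for cytotoxicity, read by MTT assay, with a stated time of 48 h; a higher number here means a weaker inhibitor, a lower number a stronger inhibitor. Compound 1 gives 20300 nM, the higher of the two numbers, and its nearest neighbour is compound 2 with 15700 nM. For the measured compounds named here, the single measured step, a 1.3-fold lower number from compound 1 to compound 2 (0.11 log units; within the scatter), swaps the group on the carbonyl carbon and stays within the scatter, so the two measured values cannot be told apart.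

Compound 3 `Nc1ccc2sc(NC(=S)NC(=O)N3CCOCC3)nc2c1` differs from compound 1 at another place: amino in place of bromo on an aromatic carbon. Going by the values given here, no measured step alters the aromatic ring, so nothing measured bears directly on this change. Among the compounds with values here, the only available step, which touched the carbonyl side, was within the scatter. With no evidence pointing either way, the expectation is that compound 3 also shows no step beyond the scatter, while the range is kept wide to reflect the lack of data. For compound 3 the estimated value in this assay is 20000 nM, with a range from 7000 nM to 60000 nM. Starting from compound 1, the expected step is a 1.0-fold lower number from compound 1 to compound 3 (0.01 log units; within the scatter).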

Compound 3, half-maximal inhibitory concentration: 19200 nM
Compound 3: the middle estimate sits 1.0-fold (0.02 log units) above what was measured; the range from low to high includes it.
By their numbers in this assay, from the lowest: compounds 2, 3 and 1 (each within the scatter of the next).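

For the compounds shown here, this is the first look at the aromatic carbon of the shared core, where amino takes the place of bromo. In this assay this change gives a 1.1-fold lower number from compound 1 to compound 3 (0.02 log units; within the scatter), so the two groups cannot be told apart at this position, at least with morpholin-4-yl on the carbonyl carbon. The swap exchanges one heavy atom for another and adds a hydrogen-bond donor and a hydrogen-bond acceptor, yet the reading does not move beyond the usual scatter, and no supporting measurement is available to explain this result.

Going by these compounds, whether the same holds for other groups on this aromatic carbon, such as a carboxylic acid, a methoxy group or a longer chain, remains open. Also open, on these data alone, is whether amino in place of bromo would give a similar result with thiophen-2-yl on the carbonyl carbon, the group carried by compound 2.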